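Larger amino group on the triazine core of compound 1

The source may hold more compounds than are shown below. What is called first, only, known or untested is meant among the compounds shown, and "the series" means these compounds.

Among the compounds with values here, compound 1 `CNc1nc(Cl)nc(N[C@@H](C)c2ccccc2)n1` is the weaker of the two compounds measured so far in an ADME assay on the whole organism for inhibition, with Echinochloa crus-galli var. formosensis as the target, with a stated time of 4 days; a lower number here means a stronger inhibitor, a higher number a weaker inhibitor: in this assay compound 1 gives 26900 nM, the highest of the two numbers recorded. Compound 2 `CC[C@@H](C)Nc1nc(Cl)nc(N[C@H](C)c2ccccc2)n1` gives 4570 nM in this assay, a step of more than the usual scatter below compound 1. Compound 3 `CCN(c1nc(Cl)nc(N[C@@H](C)c2ccccc2)n1)C(C)C` has not yet been measured. It differs from compound 1 in one place: ethyl(isopropyl)amino in place of methylamino on an aromatic carbon. Compound 2 already carries a larger amino group than compound 1 on the shared core and gives a lower number, so the account expects the step of a 3.0-fold lower number from compound 1 to compound 3 (0.48 log units; beyond the scatter) in this assay to run in the same downward direction and to be beyond the scatter. On this basis compound 3 is estimated to give 9000 nM in this assay, with an expected range from 3000 nM to 27000 nM.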

Compound 3, half-maximal inhibitory concentration: 229 nM
For compound 3 the middle estimate is 39-fold (1.59 log units) above the measured one, outside the stated range (below it).
By their numbers in this assay, from the lowest: compound 3; then compound 2; then compound 1.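

Within the data shown here, at this position of the shared core, ethyl(isopropyl)amino in place of methylamino gives a 120-fold lower number from compound 1 to compound 3 (2.07 log units; beyond the scatter) in this assay, the first step here that can be read as a change in one place, and it is a large one. The change raises the group from 2 to 6 heavy atoms and lowers its hydrogen-bond donors from 1 to 0, and this single step cannot separate those two differences. Nothing measured here bears on why the number falls so far.

On these data alone, it remains open whether an isopropylamino group, which keeps the hydrogen on the nitrogen, or a dimethylamino group, which does not, would carry much of this step. Also open, as far as these compounds go, is how a longer chain on that nitrogen, or a ring such as piperidine in its place, would read in this assay.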